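Swapping the aryl ether back to an anilide linker

A few compounds are considered here, and "the series" means these few. Any claim that something is new, unique, unknown or untested is made for them only; others in the source may bear on it.

Within the data shown here, compound 2 `Cc1cc(-c2cnn3c(NCC4CCOCC4)nc(Oc4cccc(F)c4F)nc23)ccc1C(=O)NC1CC1` stands lowest of the two numbers so far, giving 9 nM in a functional assay on HCT-116 cells (Homo sapiens) for antiproliferative activity; a lower number here means a stronger inhibitor of growth, a higher number a weaker inhibitor of growth; compound 1 `Cc1cc(-c2cnn3c(NCC4CCOCC4)nc(Nc4ccccc4)nc23)ccc1C(=O)NC1CC1` gives 690 nM. Among the measured compounds shown here, the one measured step bearing on the question is a 77-fold lower number from compound 1 to compound 2 (1.88 log units; beyond the scatter). Compound 3 `Cc1cc(-c2cnn3c(NCC4CCOCC4)nc(Nc4cccc(F)c4)nc23)ccc1C(=O)NC1CC1` now carries (3-fluorophenyl)amino in place of 2,3-difluorophenoxy on an aromatic carbon, largely undoing that earlier change while keeping a single fluorine. A substantial rise in this assay is therefore expected, though probably short of the full earlier gap, and the expected step is a 22-fold higher number from compound 2 to compound 3 (1.35 log units; beyond the scatter). Compound 3 is estimated at 200 nM, within 50 nM to 900 nM.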

Compound 3, concentration for 50% growth inhibition: 9 nM
For compound 3 the middle estimate is 22-fold (1.35 log units) above the measured one, outside the stated range (below it).
By their numbers in this assay, from the lowest: compounds 2 and 3 (each within the scatter of the next); then compound 1.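

In this assay, a phenoxy link at this position is not needed for a low number: (3-fluorophenyl)amino in place of 2,3-difluorophenoxy gives no change at the digits printed from compound 2 to compound 3 (within the scatter), even though the linking atom and the fluorine count both change. With the amino link kept, a single fluoro in place of hydrogen accounts for a 77-fold lower number from compound 1 to compound 3 (1.88 log units; beyond the scatter), so this one atom carries a large step. No evidence here explains that step. What remains open is how each linker behaves alone, since plain phenoxy and (2,3-difluorophenyl)amino are not among these compounds. On these data alone, whether chloro or methoxy could stand in for the fluorine also remains open.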